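Semicarbazone aryl swap: compound 3 on the shared core

This account rests on a few compounds, and the source may have more. Where it says the series, first, only, none or still open, it means among the compounds named here.

Two members of this series carry a value in a functional assay on HT-29 cells (Homo sapiens) for cytotoxicity, read by MTT assay, with a stated time of 72 h; a higher number here means a weaker inhibitor, a lower number a stronger inhibitor. Compound 1, `COc1cc(/C=N/NC(=O)Nc2ccc(Oc3ccnc(-c4nncn4CCN(C)C)c3)c(F)c2)cc(OC)c1OC`, gives 3620 nM. Within the data shown here, compound 2, `CN(C)CCn1cnnc1-c1cc(Oc2ccc(NC(=O)N/N=C/c3cccc(Br)c3)cc2F)ccn1`, gives 380 nM and so stands as the lower of the two numbers; the only step that joins them, a 9.5-fold lower number from compound 1 to compound 2 (0.98 log units; beyond the scatter), is beyond the scatter. Compound 3, `COc1cc(/C=N/NC(=O)Nc2ccc(Oc3ccnc(-c4nncn4CCN(C)C)c3)c(F)c2)ccc1O`, remains to be measured. Against compound 2 its difference is 4-hydroxy-3-methoxyphenyl in place of 3-bromophenyl on a carbon with a double bond to nitrogen.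

Among the measured compounds shown here, only the step from compound 1 to compound 2 bears on this change: there, a 3,4,5-trimethoxyphenyl ring on that carbon was exchanged for 3-bromophenyl and the number dropped by a 9.5-fold lower number from compound 1 to compound 2 (0.98 log units; beyond the scatter). Compound 3 moves back to an oxygen-bearing aryl, closer in kind to compound 1 than to compound 2, so a rise in this assay, roughly reversing part of that step, is the expectation; the 4-hydroxy-3-methoxyphenyl ring is not identical to the trimethoxyphenyl of compound 1, so the full reversal is uncertain. Compound 3 is therefore estimated at 1500 nM, within 500 nM to 5000 nM, which means an expected step of a 3.9-fold higher number from compound 2 to compound 3 (0.60 log units; beyond the scatter).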

Compound 3, half-maximal inhibitory concentration: 120 nM
Compound 3: the middle estimate sits 13-fold (1.10 log units) above what was measured; the whole stated range lies above it.
By their numbers in this assay, from the lowest: compound 3; then compound 2; then compound 1.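

At the carbon with a double bond to nitrogen, an oxygen-bearing aryl does not by itself bring a higher number in this assay: 4-hydroxy-3-methoxyphenyl in place of 3-bromophenyl gives a 3.2-fold lower number from compound 2 to compound 3 (0.50 log units; beyond the scatter), so the earlier drop with 3-bromophenyl does not mark bromine as the preferred substituent on this ring. The two oxygen-bearing aryl groups also stand far apart, with a 30-fold lower number from compound 1 to compound 3 (1.48 log units; beyond the scatter), which places compound 3 lowest of the three and shows that the result at this position depends on the particular substitution, not merely on the presence of oxygen substituents. No supporting data bear on why these aryl groups rank in this order.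

Going by these compounds, it remains open which part of the 4-hydroxy-3-methoxyphenyl group carries the low number in compound 3; a plain 4-hydroxyphenyl or a plain 3-methoxyphenyl group on the same carbon would separate the two substituents. Also open, on these data alone, is whether an amine or a carboxylic acid on the ring in place of the hydroxyl would keep the number of compound 3 in this assay.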